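The compounds below may be only part of what the source reports. "The series", "measured", "known", "first", "only" and "open" are said of these compounds alone.

Compound 1 `COc1cc2c(Nc3nc4ccc(C(=O)Nc5c(C)cccc5C)cc4s3)ncnc2cc1OCCCN1CCCCC1` in a functional assay on A549 cells (Homo sapiens) for cytotoxicity, read by WST assay, with a stated time of 72 h (on this read-out lower numbers stand for stronger inhibition and higher numbers for weaker inhibition), gives a limit of the assay, > 100000 nM, rather than a number.
Compound 2 `CCN(CC)CCCOc1cc2ncnc(Nc3nc4ccc(C(=O)Nc5c(C)cccc5Cl)cc4s3)c2cc1OC` gives 10600 nM in this assay.

Among the measured compounds shown here, compound 2 thus stands as the only numeric value in the set. The value of compound 1 is a limit only (the limit of > 100000 nM in this assay, at which 1 of the 2 values shown sits). Compound 3 `COc1cc2c(Nc3nc4ccc(C(=O)Nc5c(C)cccc5Cl)cc4s3)ncnc2cc1OCCCN1CCCCC1` is not yet measured in this assay. It differs from compound 2 by piperidin-1-yl in place of diethylamino on a saturated chain carbon, three bonds along the chain from an oxygen on an aromatic ring. For the measured compounds named here, no measured pair isolates this change, so the step is expected to be small, at most a mild weakening around the edge of the scatter. Compound 3 is expected to give about 16000 nM in this assay, between 5000 nM and 60000 nM, an estimated step of a 1.5-fold higher number from compound 2 to compound 3 (0.18 log units; within the scatter).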

Compound 3, half-maximal inhibitory concentration: 12800 nM
For compound 3 the middle estimate is 1.3-fold (0.10 log units) above the measured one; measured number inside the range.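

At this place on the chain, piperidin-1-yl and diethylamino are not told apart in this assay, where the step is a 1.2-fold higher number from compound 2 to compound 3 (0.08 log units; within the scatter). The pair of compound 1 and compound 3 now isolates chloro in place of methyl on an aromatic carbon, with a step of an at least 7.8-fold lower number from compound 1 to compound 3 (0.89 log units; beyond the scatter). That step starts from a limit of compound 1, not from a number: the limit of > 100000 nM in this assay, at which 1 of the 3 values shown sits.

The compounds shown leave open how morpholin-4-yl or a primary amine at the end of the chain, or a longer chain, would read. They also leave open how fluoro or methoxy in place of chloro would read.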